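Swapping trifluoromethyl for trifluoromethoxy on compound 2

The source may report more compounds than this note shows. Statements on the series, on what has been measured and on what is new or still open speak of the compounds shown alone.

Compound 1 `CC(O)(COc1ccc(S(F)(F)(F)(F)F)cc1)C(=O)Nc1cccc(S(F)(F)(F)(F)F)c1`: 10200 nM
Compound 2 `CC(O)(COc1ccc(C(F)(F)F)cc1)C(=O)Nc1cccc(S(F)(F)(F)(F)F)c1`: 3600 nM
Compound 3 `CC(O)(COc1ccccc1C(F)(F)F)C(=O)Nc1cccc(S(F)(F)(F)(F)F)c1`: 34900 nM

In a functional assay on CWR22R cells (Homo sapiens) for antiproliferative activity, read by propidium iodide staining, with a stated time of 96 h (a higher number here means a weaker inhibitor, a lower number a stronger inhibitor), compound 2 gives the lowest number of the three, 3600 nM, and the other two lie beyond the scatter from it. Compound 4 `CC(O)(COc1ccc(OC(F)(F)F)cc1)C(=O)Nc1cccc(S(F)(F)(F)(F)F)c1` has trifluoromethoxy in place of trifluoromethyl on an aromatic carbon, para to a large group (trifluoromethoxy in place of trifluoromethyl on an aromatic carbon). Among the compounds with values here, the closest precedent is the exchange of one group for another at that same place, the modest step of a 2.8-fold lower number from compound 1 to compound 2 (0.45 log units; beyond the scatter). The step of a 9.7-fold higher number from compound 2 to compound 3 (0.99 log units; beyond the scatter) is larger, but it relocates trifluoromethyl rather than replacing it. Neither step tests trifluoromethoxy directly. The expected step of a 1.1-fold higher number from compound 2 to compound 4 (0.05 log units; within the scatter) is therefore small, and is not expected to exceed the scatter in either direction. For compound 4 the estimated value is 4000 nM, with an expected range of 1600 nM to 10000 nM.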

Compound 4, half-maximal inhibitory concentration: 12900 nM
For compound 4 the middle estimate is 3.2-fold (0.51 log units) below the measured one, outside the stated range (above it).
By their numbers in this assay, from the lowest: compound 2; then compounds 1 and 4 (each within the scatter of the next); then compound 3.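

At this aromatic carbon, para to a large group, trifluoromethoxy proved no equivalent of trifluoromethyl in this assay: the result is a 3.6-fold higher number from compound 2 to compound 4 (0.55 log units; beyond the scatter). Trifluoromethoxy and the pentafluorosulfanyl group cannot be separated here (a 1.3-fold higher number from compound 1 to compound 4 (0.10 log units; within the scatter)), so among these three groups only trifluoromethyl, in compound 2, stands apart. Nothing shown gives a measured reason for this difference. As far as these compounds go, whether a nitrile or methoxy at this place would match trifluoromethyl remains open. So does how trifluoromethoxy would behave on another aromatic carbon of the same ring.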